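Methoxy in Place of Hydrogen on the Phenyl Ring of Compound 2

The compounds below may be only part of what the source reports. "The series", "measured", "known", "first", "only" and "open" are said of these compounds alone.

Measured compounds:
compound 1, `COc1cc(-c2nnc(SCC(=O)Nc3ccc(/C(C)=N/O)cc3)n2-c2ccccc2)cc(OC)c1OC` — 59%
compound 2, `C/C(=N\O)c1ccc(NC(=O)CSc2nnc(-c3ccccc3)n2-c2ccccc2)cc1` — 50%

In a functional assay on the whole organism (strain albino) for inhibition, with Rattus norvegicus as the target, read by paw edema, with stated times of 30 min and 1 h, at a dose of 0.28 mmol/kg by the oral route (on this read-out higher numbers stand for more inhibition at the one dose given (going by the name of the read-out) and lower numbers for less inhibition), compound 2 gives 50%, and its only companion, compound 1, gives 59% in this assay; the two numbers sit within the scatter of each other, so compound 2 stands nowhere apart from compound 1 on the numbers shown. Compound 3, `COc1ccc(-c2nnc(SCC(=O)Nc3ccc(/C(C)=N/O)cc3)n2-c2ccccc2)cc1`, awaits measurement. The change from compound 2 to compound 3 is methoxy in place of hydrogen on an aromatic carbon. Among the compounds with values here, one measured step bears on it: a number 9 percentage points lower from compound 1 to compound 2 (within the scatter), where phenyl replaced 3,4,5-trimethoxyphenyl. Putting one methoxy back therefore gives no reason to expect a step beyond the scatter in this assay; if anything a small rise is expected, as the step of a number 5 percentage points higher from compound 2 to compound 3 (within the scatter). Compound 3 is estimated at 55%, with a range from 42% to 68%.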

Compound 3, a percentage reported as inhibition, in the whole organism at one dose (the size of the read-out at that dose, not a potency): 45%
Estimate against measurement, compound 3: 10 percentage points above; low and high end bracket the measured number.
By their numbers in this assay, from the lowest: compounds 3, 2 and 1 (each within the scatter of the next, the first and the last beyond it).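

In this assay, a single methoxy para to a large group on the phenyl ring of compound 2 gives a number 5 percentage points lower from compound 2 to compound 3 (within the scatter) and so shows no separation from the unsubstituted ring. Within the data shown here, the new information lies in the comparison with the 3,4,5-trimethoxyphenyl group, where the change gives a number 14 percentage points lower from compound 1 to compound 3 (beyond the scatter) and is the first step in this set to pass the scatter, though only modestly, while compound 2 stays within the scatter of both neighbours. No evidence on hand bears on the reason for this result.

The three compounds cannot separate the number of methoxy groups from their places on the ring. From the compounds shown here alone, how an amine, a hydroxy group or a carboxylic acid would read at this same place also remains open.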